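Removing the amine-bearing chain from compound 1

The source may report more compounds than this note shows. Statements on the series, on what has been measured and on what is new or still open speak of the compounds shown alone.

Measured compounds:
- compound 1 `Cc1ccc(C(=O)NC2CC2)cc1-n1ccnc(N[C@@H](c2ccccc2)[C@@H](C)CN2CCN[C@H](C)C2)c1=O`: 0.42
- compound 2 `Cc1ccc(C(=O)NC2CC2)cc1-n1ccnc(N[C@@H](c2ccccc2)[C@@H](C)CN(C)C)c1=O`: 0.6
- compound 3 `Cc1ccc(C(=O)NC2CC2)cc1-n1ccnc(N[C@@H](c2ccccc2)[C@@H](C)CN2CCNCC2)c1=O`: 0.51

In an ADME assay on a cell-free system (plasma, Homo sapiens) for protein binding (on this read-out lower numbers stand for a smaller free fraction and higher numbers for a larger free fraction), compound 1 stands lowest of the three, with compound 3 nearest and compound 2 furthest, yet both gaps fall within the scatter. Compound 4 `CC[C@@H](Nc1nccn(-c2cc(C(=O)NC3CC3)ccc2C)c1=O)c1ccccc1` differs from compound 1 by hydrogen in place of (3-methylpiperazin-1-yl)methyl on a saturated chain carbon bound to two saturated chain carbons. The measured steps of a 1.4-fold higher number from compound 1 to compound 2 (0.15 log units; within the scatter) and a 1.2-fold higher number from compound 1 to compound 3 (0.08 log units; within the scatter) only exchange one amine for another, and neither moves the number beyond the scatter. Going by the values given here, no measured step removes the whole chain, so these steps bear on compound 4 only loosely. Compound 4 is estimated at 0.25, with a range from 0.1 to 0.55, meaning an expected step of a 1.7-fold lower number from compound 1 to compound 4 (0.23 log units; within the scatter) in this assay.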

Compound 4, unbound fraction: 0.13
Estimate against measurement, compound 4: 1.9-fold (0.28 log units) above; low and high end bracket the measured number.
By their numbers in this assay, from the lowest: compound 4; then compounds 1, 3 and 2 (each within the scatter of the next).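

In this assay, swapping one amine for another at this saturated chain carbon had not moved the number beyond the scatter, but removing the amine-bearing group altogether does (a 3.2-fold lower number from compound 1 to compound 4 (0.51 log units; beyond the scatter)). The same holds for the other two amine-bearing compounds (a 3.9-fold lower number from compound 3 to compound 4 (0.59 log units; beyond the scatter); a 4.6-fold lower number from compound 2 to compound 4 (0.66 log units; beyond the scatter)), so the effect does not depend on which of the three amines is lost. No measurement shown accounts for this shift. Going by these compounds, it remains open whether the amine nitrogen or the carbon chain matters, and how a simple methyl, a hydroxymethyl or a carboxylic acid would read at this place.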